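The source may report more compounds than this note shows. Statements on the series, on what has been measured and on what is new or still open speak of the compounds shown alone.

Of the compounds shown here, two built on one shared core have been measured in an assay on isolated protein for inhibition of protein kinase C epsilon type (Homo sapiens), read by coupled enzyme assay; a higher number here means a weaker inhibitor, a lower number a stronger inhibitor. Compound 1 `COCCc1cc(-c2ccnc3[nH]nc(C(F)(F)F)c23)cc(C2(C#N)CC2)c1` carries a methoxymethyl group on a saturated chain carbon bound to an aromatic carbon, and in this assay compound 1 gives 145 nM. Compound 2 `N#CC1(c2cc(CC(=O)O)cc(-c3ccnc4[nH]nc(C(F)(F)F)c34)c2)CC1` carries a carboxy group on that same chain carbon, and in this assay compound 2 gives 446 nM. For the measured compounds named here, of the two numbers, compound 2 stands highest, the weaker inhibitor, and the single step joining them, a 3.1-fold higher number from compound 1 to compound 2 (0.49 log units; beyond the scatter), is a modest change beyond the scatter.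

Compound 3 `N#CC1(c2cc(CCF)cc(-c3ccnc4[nH]nc(C(F)(F)F)c34)c2)CC1` has not yet been measured. It differs from compound 2 in one place: fluoromethyl in place of carboxy on a saturated chain carbon bound to an aromatic carbon. Going by the values given here, the only measured step that bears on this is a 3.1-fold higher number from compound 1 to compound 2 (0.49 log units; beyond the scatter), where the carboxy group entered and the number rose. Compound 3 takes that group out again and puts in a group with no hydrogen-bond donors or acceptors, so the expectation is a move back toward compound 1, with the expected step being a 2.5-fold lower number from compound 2 to compound 3 (0.39 log units; beyond the scatter), a lower number. Compound 3 is therefore estimated at 180 nM, within a range from 70 nM to 450 nM.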

Compound 3, inhibition constant: 90 nM
Compound 3: middle estimate off by 2.0-fold (0.30 log units), on the high side; the measured number falls inside the stated range.
By their numbers in this assay, from the lowest: compounds 3 and 1 (each within the scatter of the next); then compound 2.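

In this assay, fluoromethyl in place of carboxy on a saturated chain carbon bound to an aromatic carbon gives a 5.0-fold lower number from compound 2 to compound 3 (0.70 log units; beyond the scatter), so the rise seen with the carboxy group is undone by a second, quite different group and not only by methoxymethyl. The other new step, with fluoro in place of methoxy on a saturated chain carbon, two bonds along the chain from an aromatic carbon, is a 1.6-fold lower number from compound 1 to compound 3 (0.21 log units; within the scatter), so this assay does not separate these two chain ends. Compound 2, the only one of the three with a carboxy group, is thus the weakest inhibitor of the set, and nothing available here explains what sets that group apart.

The compounds shown leave open whether an amine or a primary amide on the same chain carbon would group with compound 2 or with compounds 1 and 3, and whether a longer chain ending in fluoro would hold the number of compound 3. From the compounds shown here alone, with three compounds on one shared core, it also remains open whether these steps would keep their size on another core.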